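Nitro for Amino on the Aryl Ring: Solubility Outlook

A few compounds are considered here, and "the series" means these few. Any claim that something is new, unique, unknown or untested is made for them only; others in the source may bear on it.

Of the compounds shown here, three sharing one core have been measured in a physicochemical assay for solubility, read by LC-MS, in phosphate buffer, measured as thermodynamic solubility, with a stated time of 24 h, at pH 7.4; a higher number here means a more soluble compound, a lower number a less soluble compound. Compound 1 `COc1cccc(-c2c[nH]c3ncc(-c4cnn(C)c4)cc23)c1` gives 18000 nM in this assay. Compound 2 `Cn1cc(-c2cnc3[nH]cc(-c4cccc(C(F)(F)F)c4)c3c2)cn1` gives 1000 nM in this assay, and compound 3 `Cn1cc(-c2cnc3[nH]cc(-c4cccc(N)c4)c3c2)cn1` gives 300000 nM in this assay. Compound 3 holds the highest number of the three: the nearest is compound 1, with a 17-fold higher number from compound 1 to compound 3 (1.22 log units; beyond the scatter) read in reverse, and the furthest is compound 2, a gap summarized by a 300-fold higher number from compound 2 to compound 3 (2.48 log units; beyond the scatter).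

Compound 4 `Cn1cc(-c2cnc3[nH]cc(-c4cccc([N+](=O)[O-])c4)c3c2)cn1` differs from compound 3 in one place: nitro in place of amino on an aromatic carbon. For the measured compounds named here, no measured step involves a nitro group, so the outlook rests on how the amino group behaved against its two measured neighbours. The step of a 300-fold higher number from compound 2 to compound 3 (2.48 log units; beyond the scatter) and the step of a 17-fold higher number from compound 1 to compound 3 (1.22 log units; beyond the scatter) both show the amino group standing far above the other two substituents at that position, while an 18-fold lower number from compound 1 to compound 2 (1.26 log units; beyond the scatter) shows that the two non-amino groups themselves sit well apart. Removing the amino group is therefore expected to bring a large drop in this assay, landing compound 4 somewhere in the range occupied by compounds 1 and 2. Compound 4 is estimated at 5000 nM, between 1000 nM and 30000 nM. The change from compound 3 is expected to be a 60-fold lower number from compound 3 to compound 4 (1.78 log units; beyond the scatter).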

Compound 4, solubility: 2000 nM
Compound 4: the middle estimate sits 2.5-fold (0.40 log units) above what was measured; low and high end bracket the measured number.
By their numbers in this assay, from the lowest: compounds 2 and 4 (each within the scatter of the next); then compound 1; then compound 3.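

In this assay the replacement of amino by nitro brings a 150-fold lower number from compound 3 to compound 4 (2.18 log units; beyond the scatter) and so adds a third group to the two already seen to fall far short of amino on this aromatic carbon, leaving compound 3 alone at the top of the four compounds. Nitro and trifluoromethyl cannot be told apart here, since a 2.0-fold higher number from compound 2 to compound 4 (0.30 log units; within the scatter) stays within the usual scatter of the measurement. Methoxy stays separate from nitro, with a 9.0-fold lower number from compound 1 to compound 4 (0.95 log units; beyond the scatter) as a modest step beyond the scatter, so the three groups other than amino do not fall to one common level.

Nothing on record explains why amino stands so far from the other three groups on this carbon, and no single feature of the change can be singled out. On these data alone, it remains open whether the high number belongs to amino alone or would also appear with a methylamine, an acetamide, a carboxylic acid or a longer chain ending in an amine on the same carbon, and whether a nitrile would sit with nitro and trifluoromethyl or with methoxy.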